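A methoxy in place of bromo on the shared core

This account rests on a few compounds, and the source may have more. Where it says the series, first, only, none or still open, it means among the compounds named here.

Measured so far in a functional assay on MC-38 cells (Mus musculus) for antiproliferative activity, read by colorimetric assay and MTT assay; a higher number here means a weaker inhibitor, a lower number a stronger inhibitor:
- compound 1 `Nc1ccc(S(=O)(=O)Nc2ccc(F)c3c(Cl)c[nH]c23)cc1`: 0.11 ug/mL
- compound 2 `Nc1ccc(S(=O)(=O)Nc2ccc(Br)c3c(Cl)c[nH]c23)cc1`: 0.14 ug/mL

Only these two numbers exist so far, and compound 2 stands within the scatter of compound 1, so it holds no separate rank. The next compound to be tested is compound 3 `COc1ccc(NS(=O)(=O)c2ccc(N)cc2)c2[nH]cc(Cl)c12`, which carries methoxy in place of bromo on an aromatic carbon.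

Among the measured compounds shown here, only one measured step bears on this change, bromo in place of fluoro on an aromatic carbon. For the measured compounds named here, no measured compound carries methoxy, so that step is only an indirect guide. With a 1.3-fold higher number from compound 1 to compound 2 (0.10 log units; within the scatter) as the sole reference, no step beyond the scatter is expected in this assay, in either direction. The expected step is a 1.1-fold higher number from compound 2 to compound 3 (0.06 log units; within the scatter). Compound 3 is estimated at 0.16 ug/mL, with an expected range from 0.05 ug/mL to 0.5 ug/mL.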

Compound 3, half-maximal inhibitory concentration: 2.3 ug/mL
Compound 3: middle estimate off by 14-fold (1.16 log units), on the low side, outside the stated range (above it).
By their numbers in this assay, from the lowest: compounds 1 and 2 (each within the scatter of the next); then compound 3.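

In this assay this aromatic carbon, para to a large group, proved sensitive to the group it carries, which the two halogen compounds could not show: they differ only within the scatter (a 1.3-fold higher number from compound 1 to compound 2 (0.10 log units; within the scatter)), whereas methoxy brings a large loss in both comparisons (a 16-fold higher number from compound 2 to compound 3 (1.22 log units; beyond the scatter)) (a 21-fold higher number from compound 1 to compound 3 (1.32 log units; beyond the scatter)). Among these three compounds fluoro and bromo therefore stand together, and compound 3, with methoxy, is the weakest inhibitor. Nothing available explains why this change costs so much.

From the compounds shown here alone, what remains open is where other groups on this carbon would fall, for instance a methyl, a hydroxyl or an amine: with the two halogens, with methoxy or somewhere in between. With only one non-halogen group in hand, the compounds shown cannot tell whether the loss is particular to methoxy or extends to other replacements for the halogens.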